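The compounds below may be only part of what the source reports. "The series", "measured", "known", "first", "only" and "open" are said of these compounds alone.

Compound 1 `O=c1c(-c2ccc(O)cc2)coc2cc(OCCCCBr)ccc12`: 98.3%
Compound 2 `C=CCOc1ccc2c(=O)c(-c3ccc(O)cc3)coc2c1`: 100%

Both numbers come from a functional assay on mitochondria (Cricetulus griseus) for inhibition of Monoamine oxidase (Homo sapiens), tested at 9 uM; on this read-out higher numbers stand for a stronger effect at the one concentration tested and lower numbers for a weaker effect. On these two, compound 1 stands beside compound 2, separated only by a number 1.7 percentage points higher from compound 1 to compound 2 (within the scatter); both sit close to complete inhibition at the tested concentration. Compound 3 `O=C(O)CCCCCCCCCOc1ccc2c(=O)c(-c3ccc(O)cc3)coc2c1` remains unmeasured; relative to compound 1 the change is 5-carboxypentyl in place of bromo on a saturated chain carbon, four bonds along the chain from an oxygen on an aromatic ring. Within the data shown here, no measured step covers this change. Among the measured compounds shown here, the single known step, a number 1.7 percentage points higher from compound 1 to compound 2 (within the scatter), alters the same chain at a different point and lies within the scatter. The step of a number 8.3 percentage points lower from compound 1 to compound 3 (within the scatter) is therefore expected to be small, with some room downward given the ceiling. Compound 3 is estimated at 90%, range 65% to 100%.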

Compound 3, a percentage reported as inhibition, at one concentration (the size of the read-out at that concentration, not a potency): 95%
Estimate against measurement, compound 3: 5 percentage points below; the range from low to high includes it.
By their numbers in this assay, from the lowest: compounds 3, 1 and 2 (each within the scatter of the next).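

Putting 5-carboxypentyl in place of bromo, on a saturated chain carbon four bonds along the chain from an oxygen on an aromatic ring, gives in this assay a number 3.3 percentage points lower from compound 1 to compound 3 (within the scatter). This position therefore accepts a much larger end group, with a terminal carboxylic acid, and the read-out does not separate it from bromo. No evidence bears on this result. With all values near complete inhibition at one concentration, differences in potency stay hidden. As far as these compounds go, whether a terminal amine or a shorter chain ending in a carboxylic acid would read the same remains open.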